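Growth inhibition across the amide aryl group

A few compounds are considered here, and "the series" means these few. Any claim that something is new, unique, unknown or untested is made for them only; others in the source may bear on it.

Compound 1 `CN(C)C(=O)c1cc2cnc(Nc3ccc(NC(=O)C4(C(=O)Nc5ccc(F)cc5)CC4)cc3)nc2n1C1CCCC1`: 79.9%
Compound 2 `CN(C)C(=O)c1cc2cnc(Nc3ccc(NC(=O)C4(C(=O)Nc5ccc(Cl)c(C(F)(F)F)c5)CC4)cc3)nc2n1C1CCCC1`: 2.1%

Both values come from a functional assay on NCI-H460 cells (Homo sapiens) for inhibition, read by CCK-8 assay, with a stated time of 72 h, tested at 1 uM; a higher number here means more inhibition of growth at the concentration tested, a lower number less inhibition of growth. Compound 2 stands lowest of the two, at 2.1%. The next compound to read is compound 3 `CN(C)C(=O)c1cc2cnc(Nc3ccc(NC(=O)C4(C(=O)Nc5ccccc5)CC4)cc3)nc2n1C1CCCC1`, which has phenyl in place of 4-chloro-3-(trifluoromethyl)phenyl on an amide-type nitrogen. Among the compounds with values here, one measured step bears on this change: a number 77.8 percentage points lower from compound 1 to compound 2 (beyond the scatter). That step is large and introduced the same 4-chloro-3-(trifluoromethyl)phenyl group at the same place. Compound 3 lacks this group, as does compound 1 at 79.9%, so a large rise in this assay is expected. Going by these compounds, no unsubstituted phenyl has yet been measured, so how far the rise goes remains open. The expected step is a number 59.9 percentage points higher from compound 2 to compound 3 (beyond the scatter). For compound 3 the estimate is 62%, with an expected range of 30% to 85%.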

Compound 3, percent growth inhibition at one concentration: 42.4%
Beside the measured number, compound 3's estimate is 19.6 percentage points above it; the measured number falls inside the stated range.
By their numbers in this assay, from the lowest: compound 2; then compound 3; then compound 1.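

In this assay, phenyl in place of 4-chloro-3-(trifluoromethyl)phenyl on the amide-type nitrogen restores only part of the growth inhibition, giving a number 40.3 percentage points higher from compound 2 to compound 3 (beyond the scatter). Phenyl does not match 4-fluorophenyl: hydrogen in place of fluoro on an aromatic carbon gives a number 37.5 percentage points lower from compound 1 to compound 3 (beyond the scatter), so this position responds strongly even to the exchange of a single atom. With phenyl as the reference, one substituted ring reads higher and the other lower, so substitution here does not shift the reading in a single direction. No available data explain these differences.

Chloro and trifluoromethyl occur only together in these compounds, so their separate shares in the low reading of compound 2 stay open. Going by these compounds, how a ring carrying a methoxy group or an amine in place of the fluoro would read also remains open.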